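Methoxy count on the aryl ketone and growth inhibition

The compounds below may be only part of what the source reports. "The series", "measured", "known", "first", "only" and "open" are said of these compounds alone.

compound 1: `COc1cc(-c2cc(/C=C/C(=O)c3ccc(Cl)c(Cl)c3)[nH]n2)cc(OC)c1OC` — > 100000 nM
compound 2: `COc1ccc(C(=O)/C=C/c2cc(-c3cc(OC)c(OC)c(OC)c3)n[nH]2)cc1OC` — 2800 nM
compound 3: `COc1cc(C(=O)/C=C/c2cc(-c3cc(OC)c(OC)c(OC)c3)n[nH]2)cc(OC)c1OC` — not yet measured

In a functional assay on PC-3 cells (Homo sapiens) for inhibition, read by sulforhodamine B assay, with a stated time of 48 h (on this read-out lower numbers stand for stronger inhibition of growth and higher numbers for weaker inhibition of growth), compound 1 reaches only a limit, > 100000 nM. For the measured compounds named here, compound 2 gives 2800 nM, the only number. The remaining value, that of compound 1, is a limit. Going by the values given here, the single measured step, an at least 35-fold lower number from compound 1 to compound 2 (1.55 log units; beyond the scatter), rests on (the limit of > 100000 nM in this assay, at which 1 of the 2 values shown sits). Compound 3 differs from compound 2 by methoxy in place of hydrogen on an aromatic carbon. Among the compounds with values here, no measured step adds a methoxy group, so the earlier step offers little guide; the methoxy-bearing aryl ketone of compound 2 is the only number, and compound 3 is expected to stay near it, with a 1.1-fold lower number from compound 2 to compound 3 (0.05 log units; within the scatter) within the scatter. Compound 3 is estimated at 2500 nM, between 800 nM and 8000 nM.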

Compound 3, concentration for total growth inhibition: 3290 nM
Beside the measured number, compound 3's estimate is 1.3-fold (0.12 log units) below it; the measured number falls inside the stated range.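

Methoxy in place of hydrogen on an aromatic carbon, ortho to a methoxy group, gives in this assay a 1.2-fold higher number from compound 2 to compound 3 (0.07 log units; within the scatter), leaving compound 3 level with compound 2. For the compounds shown here, this is the first step between two actual numbers, and this position accepts the added methoxy. The earlier step has no such exact size, as one end is a limit: the limit of > 100000 nM in this assay, at which 1 of the 3 values shown sits.

Open, going by these compounds, is whether an amine or a hydroxy group at this position would read differently. Also open, on these data alone, is how the aryl ketone behaves with no methoxy group at all.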